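The compounds below may be only part of what the source reports. "The series", "measured", "known", "first", "only" and "open" are said of these compounds alone.

In an ADME assay on EA.hy 926 cells (Homo sapiens) for inhibition, read by MTT assay, with a stated time of 72 h (on this read-out higher numbers stand for weaker inhibition and lower numbers for stronger inhibition), compound 1 (`CCCNC(=C\C(=O)/C=C/c1ccc(O)c(OC)c1)/C=C/c1ccc(O)c(OC)c1`) gives > 25000 nM, which is a limit of the assay and not a number. Compound 2 (`CCC(C)NC(=C\C(=O)/C=C/c1ccc(OC(C)=O)c(OC)c1)/C=C/c1ccc(OC(C)=O)c(OC)c1`) gives > 25000 nM, which is also a limit. The two compounds thus share (the limit of > 25000 nM in this assay, at which 2 of the 2 values shown sit), and compound 1 has no exact value from which to measure a change. Compound 3 (`CCCCNC(=C\C(=O)/C=C/c1ccc(O)c(OC)c1)/C=C/c1ccc(O)c(OC)c1`) keeps the core of compound 1 and differs in one place, where propyl becomes butyl: methyl in place of hydrogen on a saturated chain carbon, three bonds along the chain from an amine nitrogen. Going by the values given here, no measured pair shows the effect of such a change in this assay, so no shift beyond the usual scatter is expected, in either direction. The expected change is a step that the limit leaves unreadable from compound 1 to compound 3. This expectation rests on the limit of compound 1 at > 25000 nM. Compound 3 is estimated at 30000 nM, with an expected range of 12000 nM to 60000 nM.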

Compound 3, half-maximal inhibitory concentration: > 25000 nM
Compound 3: no number, only a limit (the forecaster's own chance of this, stated with the estimate: 70%); the middle value is on the limit's open side.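

No step can be read between compound 1 and compound 3, since each gives only a limit and not a number in this assay: the limit of > 25000 nM in this assay, at which 3 of the 3 values shown sit.

The compounds shown leave open whether propyl to butyl changes inhibition at all, and how strongly any of them inhibits.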